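Removing a Trifluoromethyl Group: Compound 2 to Compound 4

The source may report more compounds than this note shows. Statements on the series, on what has been measured and on what is new or still open speak of the compounds shown alone.

Three compounds share one core. In a functional assay on ACHN cells (Homo sapiens) for inhibition, read by sulforhodamine B assay, with a stated time of 48 h (on this read-out higher numbers stand for weaker inhibition of growth and lower numbers for stronger inhibition of growth), compound 1 `O=C(Nc1cccc(-n2cc(-c3ccncc3)c(-c3ccc(Cl)c(O)c3)n2)c1)Nc1cccc(C(F)(F)F)c1` gives 1290 nM, compound 2 `COc1cc(-c2nn(-c3cccc(NC(=O)c4cccc(C(F)(F)F)c4)c3)cc2-c2ccncc2)ccc1Cl` gives 1890 nM, and compound 3 `O=C(Nc1cccc(-n2cc(-c3ccncc3)c(-c3ccc(Cl)c(O)c3)n2)c1)Nc1cc(C(F)(F)F)cc(C(F)(F)F)c1` gives 624 nM. Compound 2 carries the highest number of the three, though its gap to compound 1 lies within the scatter, while compound 3 lies beyond it. Compound 4 `COc1cc(-c2nn(-c3cccc(NC(=O)c4ccccc4)c3)cc2-c2ccncc2)ccc1Cl` differs from compound 2 by hydrogen in place of trifluoromethyl on an aromatic carbon. Within the data shown here, the one measured step that bears on this is a 2.1-fold lower number from compound 1 to compound 3 (0.32 log units; beyond the scatter), where adding a trifluoromethyl lowered the number. Compound 4 removes one instead, so a modest rise is expected, a 1.7-fold higher number from compound 2 to compound 4 (0.23 log units; within the scatter) in this assay. Compound 4 is therefore estimated at 3200 nM, with a range from 1500 nM to 7000 nM.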

Compound 4, concentration for 50% growth inhibition: 754 nM
For compound 4 the middle estimate is 4.2-fold (0.63 log units) above the measured one, outside the stated range (below it).
By their numbers in this assay, from the lowest: compounds 3, 4, 1 and 2 (each within the scatter of the next, the first and the last beyond it).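

Replacing trifluoromethyl with hydrogen gives a 2.5-fold lower number from compound 2 to compound 4 (0.40 log units; beyond the scatter) in this assay, so the plain phenyl of compound 4 stops growth more strongly than the 3-(trifluoromethyl)phenyl of compound 2. A trifluoromethyl on this ring is therefore not helpful everywhere, and the direction of its effect differs between the two cores: the same change on two cores in this assay, a 2.1-fold lower number (0.32 log units; beyond the scatter) from compound 1 to compound 3 and a 2.5-fold higher number (0.40 log units; beyond the scatter) from compound 4 to compound 2, 5.2-fold (0.71 log units) apart, beyond the scatter of two such steps.

As far as these compounds go, it remains open how an amine or a chlorine at this place would compare with hydrogen. Among these compounds, also open is what removing the single trifluoromethyl from compound 1 would do on its core.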